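This account rests on a few compounds, and the source may have more. Where it says the series, first, only, none or still open, it means among the compounds named here.

Measured in an ADME assay on BJ cells (Homo sapiens) for cytotoxicity, with a stated time of 72 h; on this read-out higher numbers stand for an effect only at larger amounts of compound and lower numbers for an effect already at smaller amounts:
- Compound 1 `C=C[C@@](C)(/C=C/c1ccc(OCc2ccccc2)cc1)CCC=C(C)C`: > 36600 nM
- Compound 2 `C=C[C@@](C)(/C=C/c1ccc(OS(=O)(=O)C(F)(F)F)cc1)CCC=C(C)C`: > 36600 nM
- Compound 3 `C=C[C@@](C)(/C=C/c1ccc(O)cc1)CCC(O)C(C)(C)O`: > 36600 nM

Each of these entries is a limit and not a number. Compound 3 therefore has no exact place in the series: its > 36600 nM is a limit, and the other two compounds offer only limits as well. The whole record in this assay is the limit of > 36600 nM in this assay, at which 3 of the 3 values shown sit.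

Compound 4 `C=C[C@@](C)(/C=C/c1ccc(O)cc1)CC/C=C/C(=O)OCC` carries 2-(ethoxycarbonyl)ethenyl in place of 1,2-dihydroxy-2-methylpropyl on a saturated chain carbon, three bonds along the chain from two double-bonded chain carbons.

Among the compounds with values here, the only measured step, a step that the two limits leave unreadable from compound 1 to compound 2, lies at another place in the molecule and has no readable size, so it bears on this change only weakly. Within the data shown here, with the limit of > 36600 nM in this assay, at which 3 of the 3 values shown sit, as the sole guide, no step beyond the scatter is expected, and a further limit is the likeliest report. The expected step is a step that the limit leaves unreadable from compound 3 to compound 4. Compound 4 is estimated at 40000 nM. The expected range for compound 4 runs from 18000 nM to 80000 nM.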

Compound 4, half-maximal effective concentration: > 36600 nM
Compound 4 gave a limit, no number; the forecaster's own chance of this, stated with the estimate: 75%; the middle value is on the limit's open side.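

Compound 3 and compound 4 both give only limits, so no step can be read between them: the limit of > 36600 nM in this assay, at which 4 of the 4 values shown sit.

The compounds shown leave open at what concentration any of them would show an effect in this assay, and whether exchanging 1,2-dihydroxy-2-methylpropyl for 2-(ethoxycarbonyl)ethenyl changes it.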